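The source may hold more compounds than are shown below. What is called first, only, known or untested is meant among the compounds shown, and "the series" means these compounds.

Among the compounds with values here, compound 2 `O=C(Nc1ccc(Cl)cc1)N[C@H]1CC[C@H](Oc2ccc(F)cc2)CC1` is one of three compounds measured in a functional assay on CRL2813 cells (Homo sapiens) for cytotoxicity, read by sulforhodamine B assay, with a stated time of 5 days; a lower number here means a stronger inhibitor, a higher number a weaker inhibitor. In this assay compound 2 gives > 20000 nM, which is a limit of the assay rather than a number. Compound 1 `COC(=O)c1ccc(NC(=O)N[C@H]2CC[C@H](Oc3ccc(F)cc3)CC2)cc1` carries a methoxycarbonyl group where compound 2 carries a chloro group; in this assay compound 1 gives 11600 nM. Within the data shown here, the only measured step that reaches compound 2 is an at least 1.7-fold higher number from compound 1 to compound 2 (0.23 log units; that floor lies within the scatter). Compound 3 `O=C(Nc1cccc(C(F)(F)F)c1)N[C@H]1CC[C@H](Oc2ccc(C(F)(F)F)cc2)CC1` carries a trifluoromethyl group on each outer ring, and in this assay compound 3 gives 460 nM; no single change links it to compound 2, so its value stands on its own.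

Compound 4 `O=C(Nc1ccccc1[N+](=O)[O-])N[C@H]1CC[C@H](Oc2ccc(F)cc2)CC1` differs from compound 2 by 2-nitrophenyl in place of 4-chlorophenyl on an amide-type nitrogen. Among the measured compounds shown here, no measured step exchanges one substituted phenyl ring on the amide-type nitrogen for another of this kind, so this change has no direct precedent. Compound 2 sits at the limit of > 20000 nM in this assay, at which 1 of the 3 values shown sits. Compound 1, its nearest relative, is also weak. A step of about an at least 1.3-fold lower number from compound 2 to compound 4 (0.12 log units; that floor lies within the scatter) is therefore expected, keeping the number in the same weak region. Compound 4 is estimated at 15000 nM, within a range from 4000 nM to 40000 nM, with a fair chance that only a limit is reported again.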

Compound 4, half-maximal inhibitory concentration: 3500 nM
Compound 4: the middle estimate sits 4.3-fold (0.63 log units) above what was measured, outside the stated range (below it).
By their numbers in this assay, from the lowest: compound 3; then compound 4; then compound 1. At a limit, above all of these: compound 2.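

In this assay, exchanging the ring on the amide-type nitrogen gives an at least 5.7-fold lower number from compound 2 to compound 4 (0.75 log units; beyond the scatter), so this position can shift the number by more than the usual scatter while the rest of the molecule stays the same. The earlier change at this ring, chloro in place of methoxycarbonyl, could not show this, as the floor of its step lay within the scatter. Compound 2 stands at a limit of the assay and not at a number, so the printed step is only a floor and its true size remains unknown: the limit of > 20000 nM in this assay, at which 1 of the 4 values shown sits.

The change from 4-chlorophenyl to 2-nitrophenyl alters both the group on the ring and where it sits, and the compounds shown cannot separate these two parts of the change. They also leave open whether a nitro group is needed at all, or whether a ring carrying an amine or a carboxylic acid in its place would give a similar number in this assay.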